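A few compounds are considered here, and "the series" means these few. Any claim that something is new, unique, unknown or untested is made for them only; others in the source may bear on it.

The three compounds share one core and differ only in the substituents on the aromatic ring. In a functional assay on HeLa cells (Homo sapiens) for inhibition, read by MTT assay, with a stated time of 72 h (on this read-out lower numbers stand for stronger inhibition and higher numbers for weaker inhibition), compound 1 `CC(C)c1cc(C(C)C)c(C(=O)/C=C/C(=O)O)c(C(C)C)c1` gives 6100 nM, and compound 3 `CCc1ccc(C(C)C)cc1C(=O)/C=C/C(=O)O` gives 4890 nM. Compound 2 `O=C(O)/C=C/C(=O)c1ccc(F)cc1` gives 28400 nM in this assay, the highest of the three numbers: compound 1 sits at a lower number beyond the scatter, and compound 3 lower still, also beyond the scatter. Within this small set, rings bearing alkyl groups give the lower numbers and the ring bearing only fluoro gives the highest.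

Compound 4 `CC(C)c1ccc(C(=O)/C=C/C(=O)O)cc1` is not yet measured. It differs from compound 2 by isopropyl in place of fluoro on an aromatic carbon: fluoro leaves and isopropyl enters on an aromatic carbon of a six-membered aromatic ring of carbon only, para to a group of 7 heavy atoms. Among the measured compounds shown here, no measured pair differs in this one place alone, so the expected size of the step rests on setting compound 2 against compounds 1 and 3, which carry isopropyl among several alkyl groups, where compound 4 carries one. The step expected from compound 2 to compound 4 in this assay is a 2.4-fold lower number from compound 2 to compound 4 (0.37 log units; beyond the scatter), toward a lower number, likely beyond the scatter yet smaller than the gaps to compound 1 and compound 3. Compound 4 is therefore estimated at 12000 nM in this assay, with a range from 5000 nM to 30000 nM.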

Compound 4, half-maximal inhibitory concentration: 4900 nM
Compound 4: middle estimate off by 2.4-fold (0.39 log units), on the high side; measured number outside the range, below it.
By their numbers in this assay, from the lowest: compounds 3, 4 and 1 (each within the scatter of the next); then compound 2.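

Isopropyl in place of fluoro on an aromatic carbon, para to a group of 7 heavy atoms, gives in this assay a 5.8-fold lower number from compound 2 to compound 4 (0.76 log units; beyond the scatter) as the first step that can be read at one place alone. Compounds 1 and 3 carry isopropyl only together with other alkyl groups, so they could not assign any step to this position, whereas this pair shows that exchanging this single substituent is enough to move the number beyond the scatter. Nothing available explains why the exchange has this effect.

What the compounds shown leave open is whether this step is particular to isopropyl or follows from any alkyl group at this place, which a methyl group, a longer chain such as n-butyl or a tert-butyl group would test, along with plain hydrogen as the reference point. A methoxy group or an amine at the same place would show whether groups other than alkyl also give a lower number than fluoro does.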